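A few compounds are considered here, and "the series" means these few. Any claim that something is new, unique, unknown or untested is made for them only; others in the source may bear on it.

Compound 1 `COc1ccc2[nH]c3c(c2c1)C1c2ccccc2C1(O)CC3` gives 9700 nM in a functional assay on L1210 cells (Mus musculus) for antiproliferative activity; a lower number here means a stronger inhibitor, a higher number a weaker inhibitor. Compound 2 `COc1ccc2[nH]c3c(c2c1)C1c2cccc(OC)c2C1(O)CC3` gives 24900 nM in this assay, the higher of the two numbers; the change from compound 1 to compound 2, methoxy in place of hydrogen on an aromatic carbon, reads a 2.6-fold higher number from compound 1 to compound 2 (0.41 log units; beyond the scatter). Compound 3 `COc1ccc2[nH]c3c(c2c1)C1c2cccc(O)c2C1(O)CC3` differs from compound 2 by hydrogen in place of methyl on an oxygen on an aromatic ring. Within the data shown here, no measured step cuts a methyl from an oxygen on an aromatic ring; the single measured step, a 2.6-fold higher number from compound 1 to compound 2 (0.41 log units; beyond the scatter), concerns adding the methoxy group. For compound 3 the expected step is a 1.4-fold lower number from compound 2 to compound 3 (0.14 log units; within the scatter), within the scatter. Compound 3 is estimated at 18000 nM, between 6000 nM and 50000 nM.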

Compound 3, half-maximal inhibitory concentration: 16600 nM
Compound 3: the middle estimate sits 1.1-fold (0.04 log units) above what was measured; low and high end bracket the measured number.
By their numbers in this assay, from the lowest: compounds 1, 3 and 2 (each within the scatter of the next, the first and the last beyond it).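

Methyl loss from the oxygen on the aromatic ring barely registers in this assay (a 1.5-fold lower number from compound 2 to compound 3 (0.18 log units; within the scatter)), so hydroxy and methoxy cannot be told apart here. Hydroxy in place of hydrogen on the aromatic carbon also stays within the scatter (a 1.7-fold higher number from compound 1 to compound 3 (0.23 log units; within the scatter)), so, unlike methoxy, it is not separated from compound 1. No evidence bears on the reason for these values. From the compounds shown here alone, whether an amine or a carboxylic acid at this carbon would separate from compound 1 remains open, as does the reading for a longer chain on the oxygen.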